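This account rests on a few compounds, and the source may have more. Where it says the series, first, only, none or still open, it means among the compounds named here.

In a functional assay on CEM-SS cells (Homo sapiens) for cytotoxicity (a lower number here means a stronger inhibitor, a higher number a weaker inhibitor), compound 1 `Nc1nc2cc(Cl)c(Cl)cc2n1Cc1cccc(C(F)(F)F)c1` gives a number, 34000 nM. Compound 2 `Cc1cccc(Cn2c(Cl)nc3cc(Cl)c(Cl)cc32)c1` stands only at a limit of this assay, > 100000 nM, and has no number of its own. Compound 3 `FC(F)(F)c1cccc(Cn2c(Cl)nc3cc(Cl)c(Cl)cc32)c1` has trifluoromethyl in place of methyl on an aromatic carbon. Within the data shown here, no measured pair shows this change, so the expectation leans on compound 1, which carries trifluoromethyl and reads 34000 nM. A modest move toward stronger inhibition in this assay is expected, with the estimated step being an at least 1.6-fold lower number from compound 2 to compound 3 (0.22 log units; that floor lies within the scatter). For compound 3 the estimated value is 60000 nM, with an expected range of 25000 nM to 100000 nM.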

Compound 3, half-maximal inhibitory concentration: > 100000 nM
Compound 3: no number, only a limit; the forecaster's own chance of this, stated with the estimate: 45%; middle value at least 1.6-fold (0.22 log units) from the limit.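

In this assay compound 3 gives > 100000 nM as a limit and not a number, so trifluoromethyl on this aromatic carbon does not bring the chloro series into a readable range. The step for trifluoromethyl in place of methyl cannot be read, because both of its compounds sit at a limit: the limit of > 100000 nM in this assay, at which 2 of the 3 values shown sit. Chloro in place of amino on an aromatic carbon gives an at least 2.9-fold higher number from compound 1 to compound 3 (0.46 log units; beyond the scatter) as the only readable step, and it points to amino as the place where a number appears.

From the compounds shown here alone, whether a nitrile or a carboxylic acid on this aromatic carbon would give a number remains open. Going by these compounds, whether a longer amine in place of amino would keep a readable value is also open.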